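Halogen swap on the fused ring: fluoro to chloro

A few compounds are considered here, and "the series" means these few. Any claim that something is new, unique, unknown or untested is made for them only; others in the source may bear on it.

For the measured compounds named here, compound 3 `CC/C(=C(/c1ccc(/C=C/C(=O)O)cc1)c1ccc2[nH]ncc2c1F)c1ccccc1` gives 8200 ng.h/mL in an ADME assay on the whole organism (strain CD-1) for pharmacokinetics, with Mus musculus as the target, at a dose of 10 mg/kg by the oral route (on this read-out higher numbers stand for higher exposure at the dose given and lower numbers for lower exposure), the second highest of the three numbers so far. Its nearest neighbour is compound 1 `CC/C(=C(/c1ccc(/C=C/C(=O)O)cc1)c1ccc2[nH]ncc2c1)c1ccccc1` at 5800 ng.h/mL; its furthest is compound 2 `CC/C(=C(/c1ccc(/C=C/C(=O)O)cc1)c1ccc2[nH]nc(F)c2c1)c1ccccc1` at 14000 ng.h/mL, and a 1.7-fold lower number from compound 2 to compound 3 (0.23 log units; within the scatter). Compound 4 `CC/C(=C(/c1ccc(/C=C/C(=O)O)cc1)c1ccc2[nH]ncc2c1Cl)c1ccccc1` differs from compound 3 by chloro in place of fluoro on an aromatic carbon. Going by the values given here, no measured step swaps one halogen for another; the nearest comparisons are the halogen-for-hydrogen steps a 1.4-fold higher number from compound 1 to compound 3 (0.15 log units; within the scatter) and a 2.4-fold higher number from compound 1 to compound 2 (0.38 log units; beyond the scatter), one within the scatter and one modest. On that basis no step beyond the scatter is expected in this assay, a 1.0-fold lower number from compound 3 to compound 4 (0.01 log units; within the scatter). Compound 4 is therefore estimated at 8000 ng.h/mL, with a range of 3500 ng.h/mL to 18000 ng.h/mL.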

Compound 4, area under the concentration-time curve: 18000 ng.h/mL
For compound 4 the middle estimate is 2.3-fold (0.35 log units) below the measured one; measured number inside the range.
By their numbers in this assay, from the lowest: compounds 1, 3, 2 and 4 (each within the scatter of the next, the first and the last beyond it).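

In this assay, for the compounds shown here, the identity of the halogen on this aromatic carbon matters: a 2.2-fold higher number from compound 3 to compound 4 (0.34 log units; beyond the scatter) is the first halogen-for-halogen step. Fluoro in place of hydrogen here stayed within the scatter, whereas chloro in place of hydrogen gives a 3.1-fold higher number from compound 1 to compound 4 (0.49 log units; beyond the scatter) and so clears it. Moving to the 4-chloro-1H-indazol-5-yl compound from the 3-fluoro-1H-indazol-5-yl compound gives a 1.3-fold higher number from compound 2 to compound 4 (0.11 log units; within the scatter), so these two cannot be ordered.

As far as these compounds go, whether bromo or methyl on this carbon would exceed chloro remains open. Nothing available accounts for the step from fluoro to chloro.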